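Dihydroquinolinone sulfonamides: aryl swap at the saturated carbon

The source may report more compounds than this note shows. Statements on the series, on what has been measured and on what is new or still open speak of the compounds shown alone.

Measured so far in a functional assay on Ehrlich cells (Mus musculus) for antiproliferative activity, read by trypan blue exclusion, with a stated time of 2 h, tested at 10 ug/mL; on this read-out lower numbers stand for a weaker effect and higher numbers for a stronger effect at the one concentration tested:
- compound 1, `N#CC1=C(N)N(c2ccc(S(N)(=O)=O)cc2)C2=C(C(=O)CCC2)C1c1ccc(O)cc1`: 90%
- compound 2, `N#CC1=C(N)N(c2ccc(S(N)(=O)=O)cc2)C2=C(C(=O)CCC2)C1/C=C/c1ccccc1`: 2%
- compound 3, `COc1cc(CC2C(C#N)=C(N)N(c3ccc(S(N)(=O)=O)cc3)C3=C2C(=O)CCC3)ccc1O`: 0%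

Compound 3 holds the lowest number of the three in this assay, but the gap to compound 2, a number 2 percentage points lower from compound 2 to compound 3 (within the scatter), lies within the scatter, so the two are not separated; only compound 1 stands apart, with a number 90 percentage points lower from compound 1 to compound 3 (beyond the scatter) and a number 88 percentage points lower from compound 1 to compound 2 (beyond the scatter).

Compound 4, `COc1ccc2ccccc2c1C1C(C#N)=C(N)N(c2ccc(S(N)(=O)=O)cc2)C2=C1C(=O)CCC2`, differs from compound 3 by 2-methoxynaphthalen-1-yl in place of 4-hydroxy-3-methoxybenzyl on a saturated ring carbon.

Bearing on this step: both replacements of 4-hydroxyphenyl on the saturated ring carbon, by 2-phenylethenyl and by 4-hydroxy-3-methoxybenzyl, gave large losses, while the step between those two larger groups stayed within the scatter. A further change to another large group without a hydrogen-bond donor is therefore expected to give no step beyond the scatter in this assay, a number 5 percentage points higher from compound 3 to compound 4 (within the scatter). Compound 4 is estimated at 5%, with a range from 0% to 35%.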

Compound 4, a percentage reported as activity, at one concentration (the size of the read-out at that concentration, not a potency): 40%
Compound 4: the middle estimate sits 35 percentage points below what was measured; measured number above the stated range.
By their numbers in this assay, from the lowest: compounds 3 and 2 (each within the scatter of the next); then compound 4; then compound 1.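

In this assay the saturated ring carbon does not fall to the bottom of the range with every large group: the change gives a number 40 percentage points higher from compound 3 to compound 4 (beyond the scatter) and also a number 38 percentage points higher from compound 2 to compound 4 (beyond the scatter) with 2-methoxynaphthalen-1-yl in place. Compound 1 still stands apart, with a number 50 percentage points lower from compound 1 to compound 4 (beyond the scatter) on this change, so the 2-methoxynaphthalen-1-yl group recovers only part of the number seen with 4-hydroxyphenyl. A hydrogen-bond donor on the group does not sort these compounds, since compound 4 has none on 2-methoxynaphthalen-1-yl yet stands above compound 3, whose 4-hydroxy-3-methoxybenzyl carries one.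

Nothing at hand explains why these groups separate as they do. Open, as far as these compounds go, is how a plain phenyl, a 4-aminophenyl or a 4-carboxyphenyl at this carbon would compare with 4-hydroxyphenyl and 2-methoxynaphthalen-1-yl.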